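The source may hold more compounds than are shown below. What is called first, only, known or untested is meant among the compounds shown, and "the series" means these compounds.

Values in a functional assay on cells (T-cell line, Homo sapiens) for inhibition; on this read-out higher numbers stand for weaker inhibition and lower numbers for stronger inhibition:
- compound 1 `COc1ccc(CCCN2CCC(COCc3ccc(Cl)c(Cl)c3)CC2)cc1`: 200 nM
- compound 2 `COc1ccc(CCCN2CCC(COCC3CCCCC3)CC2)cc1`: 3000 nM
- compound 3 `CCN1CCC(COC(c2ccccc2)c2ccccc2)CC1`: > 20000 nM (a limit)

Compound 3 gives only a limit, > 20000 nM, so no number exists from which to count a step.

Compound 4 `CCCCCCCCCCN1CCC(COC(c2ccccc2)c2ccccc2)CC1` differs from compound 3 by one change: octyl in place of hydrogen on a saturated chain carbon, two bonds along the chain from an amine nitrogen in a ring. The same difference reads as ethyl to decyl.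

For the measured compounds named here, no measured step alters this chain. Going by the values given here, the only measured step, a 15-fold higher number from compound 1 to compound 2 (1.18 log units; beyond the scatter), is large but lies elsewhere in the structure, so it bears only indirectly: it shows that a single change can move this assay substantially. Neither compound 1, at 200 nM, nor compound 2, at 3000 nM, carries the ethyl of compound 3, and both give numbers rather than a limit. On that thin basis, a large move towards stronger inhibition is expected, estimated as an at least 13-fold lower number from compound 3 to compound 4 (1.12 log units; beyond the scatter). The uncertainty is wide, and a second limit remains possible. For compound 4 the estimated value is 1500 nM, with an expected range of 300 nM to 8000 nM.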

Compound 4, half-maximal inhibitory concentration: 2600 nM
The estimate for compound 4 lay 1.7-fold (0.24 log units) below the measured number; the measured number falls inside the stated range.
By their numbers in this assay, from the lowest: compound 1; then compounds 4 and 2 (each within the scatter of the next). At a limit, above all of these: compound 3.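

In this assay, octyl in place of hydrogen on a saturated chain carbon, two bonds along the chain from an amine nitrogen in a ring, gives an at least 7.6-fold lower number from compound 3 to compound 4 (0.88 log units; beyond the scatter). No other step shown alters this chain, so this is the only direct sign that the position responds: the decyl of compound 4 yields a number, whereas the ethyl of compound 3 yields none. The size of the step remains a bound because compound 3 gives only a limit: the limit of > 20000 nM in this assay, at which 1 of the 4 values shown sits.

The compounds shown leave open how the number runs with chain length between ethyl and decyl, and whether a longer chain than decyl moves it further. They also leave open whether an amine or a carboxylic acid at the end of the chain would keep the gain, and whether the same change carries over to the core of compound 1.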